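Changing the pyrazole attachment on a cycloheptyl urea

A few compounds are considered here, and "the series" means these few. Any claim that something is new, unique, unknown or untested is made for them only; others in the source may bear on it.

Of the compounds shown here, two have been measured in an assay on microsomes from intestine for inhibition of acyl-CoA:cholesterol acyltransferase (Oryctolagus cuniculus); a higher number here means a weaker inhibitor, a lower number a stronger inhibitor. Compound 2 `Cc1cc(C)c(NC(=O)N(Cc2ccc(-n3cccn3)cc2)C2CCCCCC2)c(C)c1` gives 70 nM in this assay, and compound 1 `Cc1cc(C)c(NC(=O)N(Cc2ccc(-c3cccnc3)cc2)C2CCCCCC2)c(C)c1` gives 130 nM; the step of a 1.9-fold lower number from compound 1 to compound 2 (0.27 log units; within the scatter) is within the scatter, so the two stand level. Compound 3 `Cc1cc(C)c(NC(=O)N(Cc2ccc(-c3ccn(C)n3)cc2)C2CCCCCC2)c(C)c1` differs from compound 2 only by 1-methyl-1H-pyrazol-3-yl in place of 1H-pyrazol-1-yl on an aromatic carbon. For the measured compounds named here, the single step that bears on this region of the molecule was small, so for compound 3 no change beyond the scatter is expected in this assay. Compound 3 is therefore estimated at 90 nM, with a range from 35 nM to 230 nM. The expected step is a 1.3-fold higher number from compound 2 to compound 3 (0.11 log units; within the scatter).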

Compound 3, half-maximal inhibitory concentration: 44 nM
The estimate for compound 3 lay 2.0-fold (0.31 log units) above the measured number; low and high end bracket the measured number.
By their numbers in this assay, from the lowest: compounds 3, 2 and 1 (each within the scatter of the next, the first and the last beyond it).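

In this assay the two pyrazole groups stand level: a 1.6-fold lower number from compound 2 to compound 3 (0.20 log units; within the scatter), so exchanging 1H-pyrazol-1-yl for 1-methyl-1H-pyrazol-3-yl leaves the number within the scatter. Against pyridin-3-yl, the same group gives the first step in this series beyond the scatter, though a modest one: a 3.0-fold lower number from compound 1 to compound 3 (0.47 log units; beyond the scatter). No available measurement explains this difference.

The compounds shown leave open how this position responds to a group without an aromatic ring, such as a morpholine or a carboxylic acid. They also leave open what an ethyl group in place of the methyl on the pyrazole would do.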